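The compounds below may be only part of what the source reports. "The series", "measured", "known", "first", "only" and "open" are said of these compounds alone.

In an ADME assay on BJ cells (Homo sapiens) for cytotoxicity, with a stated time of 72 h (on this read-out lower numbers stand for an effect already at smaller amounts and higher numbers for an effect only at larger amounts of compound), three compounds have been tested so far, and none has given an exact number. Compound 1 `COc1cc2ncnc(-n3nc(-c4ccc(Cl)cc4)nc3N)c2cc1OC` gives > 50000 nM, which is a limit of the assay and not a number. Compound 2 `COc1cc2nc(Cl)nc(-n3nc(-c4ccccn4)nc3N)c2cc1OC` gives > 13000 nM, also a limit. Compound 3 `CCOC(=O)CNc1nc(-n2nc(-c3ccccn3)nc2N)c2cc(OC)c(OC)cc2n1` gives > 27000 nM, again a limit, so its place among the three cannot be ranked.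

Compound 4 `CCN(CC)c1nc(-n2nc(-c3ccccn3)nc2N)c2cc(OC)c(OC)cc2n1` has diethylamino in place of ((ethoxycarbonyl)methyl)amino on an aromatic carbon, between two ring nitrogen atoms (diethylamino in place of ((ethoxycarbonyl)methyl)amino on an aromatic carbon). For the measured compounds named here, the one measured step at this position is a step that the two limits leave unreadable from compound 2 to compound 3, and it offers no size to carry over. With no measured size to go on, no change beyond the usual scatter can be forecast in this assay, and no direction can be given. The forecast therefore starts from compound 3 at > 27000 nM, a limit. The expected change is a step that the limit leaves unreadable from compound 3 to compound 4. For compound 4 the estimate is 30000 nM, with an expected range from 10000 nM to 60000 nM.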

Compound 4, half-maximal effective concentration: > 9000 nM
Compound 4 gave a limit, no number (the forecaster's own chance of this, stated with the estimate: 75%); the middle value is on the limit's open side.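

Compound 4 gives > 9000 nM, again a limit and not a number. The steps from compound 2 and compound 3 to compound 4 therefore cannot be read. The compounds shown leave open whether chloro, ((ethoxycarbonyl)methyl)amino or diethylamino at this place makes any difference to the effect on the cells.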